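The source may report more compounds than this note shows. Statements on the series, on what has been measured and on what is new or still open speak of the compounds shown alone.

Working notes on the series. Among the measured compounds shown here, compound 1 `COc1cc(NC(=O)c2cnc(C)cn2)c2ncccc2c1` is the only member with a number so far: in a functional assay on PANC-1 cells (Homo sapiens) for inhibition, read by MTT assay, with a stated time of 72 h (a lower number here means a stronger inhibitor, a higher number a weaker inhibitor), compound 1 gives 800 nM. Compound 2 `NCCOc1cc(NC(=O)c2cnccn2)c2ncccc2c1` returns no number in this assay, and compound 2 gives > 10000 nM, which is a limit of the assay. Compound 2 therefore stands at the limit of > 10000 nM in this assay, at which 1 of the 2 values shown sits, the weak end of what is shown, with nothing to place it more closely. Compound 1 and compound 2 differ in two places, so their two values show only that one sits at a number and the other at the limit.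

Compound 3 `Cc1cnc(C(=O)Nc2cc(OCCN)cc3cccnc23)cn1` is the unmeasured member. The change from compound 2 to compound 3 is methyl in place of hydrogen on an aromatic carbon. For the measured compounds named here, no single-change step has been measured in this set, so the size of the move in this assay is open; the methylpyrazine is shared with compound 1, whose value of 800 nM is the one number available. The expected step is an at least 1.2-fold lower number from compound 2 to compound 3 (0.09 log units; that floor lies within the scatter), not clearly beyond the scatter. Compound 3 is expected at 8000 nM in this assay, within 2000 nM to 30000 nM.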

Compound 3, half-maximal inhibitory concentration: > 10000 nM
Compound 3: only a limit was reported; the forecaster's own chance of this, stated with the estimate: 50%; at least 1.2-fold (0.09 log units) between middle value and limit.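

In this assay compound 3 gives > 10000 nM, which is a limit of the assay. Among the compounds shown here, compound 1 and compound 3 share the methylpyrazine and differ in one place, aminomethyl in place of hydrogen on a saturated chain carbon bound to an oxygen on an aromatic ring, and this change gives an at least 12-fold higher number from compound 1 to compound 3 (1.09 log units; beyond the scatter), the first readable single-change step in the set. The 5-methylpyrazin-2-yl group does not bring the aminomethyl-bearing compound 3 to a number, and the step between compound 2 and compound 3 cannot be read, with both compounds at the same end of the range: the limit of > 10000 nM in this assay, at which 2 of the 3 values shown sit.

On these data alone, how far compound 2 and compound 3 lie past the limit remains open, and so does any effect of the methyl on the amine-bearing compounds. Also open, as far as these compounds go, is whether the large step follows the amine itself or the added chain carbon, a question that a hydroxyl, a dimethylamine or a carboxylic acid in place of the amine, or a longer chain, would address.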